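From nitro to bromo: an estimate for compound 4

A few compounds are considered here, and "the series" means these few. Any claim that something is new, unique, unknown or untested is made for them only; others in the source may bear on it.

Compound 1 `C/C=C/C(=O)N(Cc1ccc(OC)c([N+](=O)[O-])c1)c1cc(OC)c(OC)c(OC)c1` carries a (prop-1-en-1-yl)carbonyl group on its nitrogen, and in a functional assay on MGC-803 cells (Homo sapiens) for inhibition, read by MTT assay, with a stated time of 48 h (a lower number here means a stronger inhibitor, a higher number a weaker inhibitor), compound 1 gives 590 nM. Going by the values given here, that places it in the middle of the three numbers known so far. Compound 3 `C#CC(=O)N(Cc1ccc(OC)c(O)c1)c1cc(OC)c(OC)c(OC)c1` gives a lower number, 170 nM, and compound 2 `COc1ccc(CNc2cc(OC)c(OC)c(OC)c2)cc1[N+](=O)[O-]` a higher one, 19400 nM.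

Compound 4 `C/C=C/C(=O)N(Cc1ccc(OC)c(Br)c1)c1cc(OC)c(OC)c(OC)c1` keeps the core of compound 1 and its (prop-1-en-1-yl)carbonyl group, but one substituent changes: bromo in place of nitro on an aromatic carbon. The exchanged group sits ortho to a methoxy group.

Among the compounds with values here, only one measured step is available: a 33-fold higher number from compound 1 to compound 2 (1.52 log units; beyond the scatter). This large step has hydrogen in place of (prop-1-en-1-yl)carbonyl on the nitrogen. That is a different place from the nitro group, so it gives no direct guide to the new change. Compound 3 differs from compound 1 in more than one place, so it cannot isolate the nitro group either. Within the data shown here, no measured pair shows what replacing nitro does, and nothing favours a direction.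

The estimated step is a 1.2-fold lower number from compound 1 to compound 4 (0.07 log units; within the scatter), so no change beyond the scatter is expected. For compound 4 the estimated value in this assay is 500 nM, with an expected range from 150 nM to 1800 nM.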

Compound 4, half-maximal inhibitory concentration: 6430 nM
Beside the measured number, compound 4's estimate is 13-fold (1.11 log units) below it, outside the stated range (above it).
By their numbers in this assay, from the lowest: compound 3; then compound 1; then compound 4; then compound 2.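

In this assay, the aromatic carbon ortho to a methoxy group proves sensitive to what it carries: with the rest of the molecule unchanged, bromo in place of nitro gives an 11-fold higher number from compound 1 to compound 4 (1.04 log units; beyond the scatter). Going by these compounds alone, until now, the only single-place change measured was at the nitrogen, a 33-fold higher number from compound 1 to compound 2 (1.52 log units; beyond the scatter), so there are now two places on compound 1 where one change gives a large step to a weaker inhibitor. The exchange removes nitro, with 3 heavy atoms and 2 hydrogen-bond acceptors, and brings in bromo, with 1 heavy atom and 0 hydrogen-bond acceptors, but no measurement here tells which difference, if any, accounts for the step.

The compounds shown leave open how other groups would fare on this carbon, such as chloro, a nitrile or an amine, and whether any of them would match nitro or fall nearer bromo. On these data alone, it also remains open whether bromo in place of nitro gives a similar step when the nitrogen carries a different group, such as a longer acyl chain.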